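The compounds below may be only part of what the source reports. "The series", "measured", "known", "first", "only" and "open" are said of these compounds alone.

In an ADME assay on Akata cells (Homo sapiens) for cytotoxicity (a higher number here means that more compound is tolerated, a lower number that less compound is tolerated), compound 1 (`Nc1nc2c(ncn2/C=C2\C[C@@H]2[C@H](O)CO)c(=O)[nH]1`) gives 67000 nM. Compound 2 (`Nc1ncnc2c1ncn2/C=C1/C[C@H]1[C@H](O)CO`) gives 93500 nM and compound 3 (`Nc1ncnc2c1ncn2/C=C1\C[C@H]1[C@H](O)CO`) gives 72700 nM. All three values lie within the scatter of one another, so compound 1 has no distinct place among them. Compound 4 (`Nc1nc2c(ncn2/C=C2/C[C@@H]2[C@H](O)CO)c(=O)[nH]1`) departs from compound 1 as follows: the two compounds have the same atoms and bonds and differ only in configuration as drawn: 1 of 3 stereo elements differ; a double bond is drawn E in compound 1 and Z in compound 4. The shared core of compound 1 and compound 4 differs from that of compound 2 and compound 3, so the comparison is only by analogy.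

Among the measured compounds shown here, the one measured step of this kind is a 1.3-fold lower number from compound 2 to compound 3 (0.11 log units; within the scatter). The sole difference there is the fact that compounds 2 and 3 differ only in the configuration as drawn, with the double bond drawn Z in compound 2 and E in compound 3. Compound 1 to compound 4 runs the opposite way, from E to Z, so only a small rise in this assay is expected, and none beyond the scatter. The expected change is a 1.2-fold higher number from compound 1 to compound 4 (0.08 log units; within the scatter). Compound 4 is estimated at 80000 nM, with an expected range of 48000 nM to 130000 nM.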

Compound 4, half-maximal cytotoxic concentration: 54000 nM
The estimate for compound 4 lay 1.5-fold (0.17 log units) above the measured number; measured number inside the range.
By their numbers in this assay, from the lowest: compounds 4, 1, 3 and 2 (each within the scatter of the next).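

In this assay, moving the double bond from E to Z on the core of compound 1 gives a 1.2-fold lower number from compound 1 to compound 4 (0.09 log units; within the scatter). With a 1.3-fold lower number from compound 2 to compound 3 (0.11 log units; within the scatter), the double-bond geometry now has a reading on two different cores, and neither step leaves the scatter. On these two pairs, the geometry at this double bond therefore has no discernible bearing on the tolerated concentration, and the change in the new pair is confined to this one feature: the fact that compounds 1 and 4 differ only in the configuration as drawn

On these data alone, all four compounds carry the same hydroxyl-bearing side chain, so the effect of an amine, a carboxylic acid or a longer chain in its place remains open. Also open, as far as these compounds go, is whether the double-bond geometry would still make no discernible difference with such a group present.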